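Phenyl replacing cyanopyridinyl on the triazolyl-biphenyl series

The source may hold more compounds than are shown below. What is called first, only, known or untested is meant among the compounds shown, and "the series" means these compounds.

Compound 1 `N#Cc1cncc(-c2ccc(-n3cc(-c4ccccc4)nn3)cc2)c1` is measured in a functional assay on MCF7 cells (Homo sapiens) for inhibition, read by resazurin assay, with a stated time of 72 h (a higher number here means a weaker inhibitor, a lower number a stronger inhibitor), as a limit of the assay only, < 50000 nM, not as a number. Compound 2 `COc1ccc(F)cc1-c1ccc(-n2cc(-c3ccccc3)nn2)cc1` likewise gives only a limit, < 50000 nM. Both values sit at the limit of < 50000 nM in this assay, at which 2 of the 2 values shown sit, so compound 1 cannot be placed against anything within the series. Compound 3 `c1ccc(-c2ccc(-n3cc(-c4ccccc4)nn3)cc2)cc1` differs by phenyl in place of 5-cyanopyridin-3-yl on an aromatic carbon. Going by the values given here, with no measured step to lean on, the expected change from compound 1 to compound 3 is a step that the limit leaves unreadable from compound 1 to compound 3, nothing beyond the scatter. Compound 3 is estimated at 20000 nM, between 3000 nM and 50000 nM.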

Compound 3, half-maximal inhibitory concentration: < 50000 nM
Compound 3: only a limit was reported; the forecaster's own chance of this, stated with the estimate: 60%; the middle value lies beyond the limit too.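

No step can be read from compound 1 to compound 3, since both give only a limit in this assay: the limit of < 50000 nM in this assay, at which 3 of the 3 values shown sit.

Any ordering of compound 1, compound 2 and compound 3 stays open, including the effect on inhibition of phenyl in place of 5-cyanopyridin-3-yl.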